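The source may report more compounds than this note shows. Statements on the series, on what has been measured and on what is new or still open speak of the compounds shown alone.

Measured compounds in a functional assay on MCF7 cells (Homo sapiens) for cytotoxicity, read by CCK-8 assay, with a stated time of 72 h; on this read-out higher numbers stand for weaker inhibition and lower numbers for stronger inhibition:
- compound 1 `COc1ccccc1/C=c1/[nH]c(=O)/c(=C\c2ccccc2OC)n(C)c1=O` gives 9000 nM
- compound 2 `COc1ccccc1/C=c1/[nH]c(=O)/c(=C\c2cccc(Cl)c2Cl)[nH]c1=O` gives "not active" (no number reported) (no number reported)
- compound 3 `C=CCn1c(=O)/c(=C\c2ccccc2OC)[nH]c(=O)/c1=C\c1ccccc1OC` gives 41100 nM

Within this small set compound 3 carries the highest of the two numbers reported; its nearest neighbour is compound 1, and the step from compound 1 to compound 3 is a 4.6-fold higher number from compound 1 to compound 3 (0.66 log units; beyond the scatter), a difference that lies beyond the scatter. Compound 2 stands apart as an entry without a number.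

Compound 4 `COc1ccccc1/C=c1/[nH]c(=O)/c(=C\c2ccccc2OC)[nH]c1=O` has not yet been measured. It differs from compound 3 by hydrogen in place of allyl on an aromatic nitrogen. Among the measured compounds shown here, the only measured step that bears on this change is the one from compound 1 to compound 3, a 4.6-fold higher number from compound 1 to compound 3 (0.66 log units; beyond the scatter), which went from methyl to allyl on the aromatic nitrogen and brought a modest rise in the number. Removing the allyl altogether goes further in the opposite direction, so a lower number is expected for compound 4, plausibly of a size comparable to or somewhat larger than that step. Compound 2, which also carries hydrogen on both ring nitrogens but a different aryl group, gave no number and offers no guidance on size.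

Compound 4 is therefore expected to give 8000 nM in this assay, with a range from 2000 nM to 30000 nM, which corresponds to an expected step of a 5.1-fold lower number from compound 3 to compound 4 (0.71 log units; beyond the scatter).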

Compound 4, half-maximal inhibitory concentration: "not active" (no number reported)
No number was reported for compound 4, so the estimate cannot be set against anything.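

In this assay, among the compounds shown here, compound 4 gives "not active" (no number reported), so no step from compound 3 to compound 4 can be read. The compounds shown leave open how hydrogen in place of allyl on the aromatic nitrogen changes the number, and whether compound 4 would give any number at all. No available evidence bears on this result.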